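This account rests on a few compounds, and the source may have more. Where it says the series, first, only, none or still open, it means among the compounds named here.

In a functional assay on KB cells (Homo sapiens) for inhibition (a lower number here means a stronger inhibitor, a higher number a weaker inhibitor), compound 1 `Cc1ccc(Cn2c(N)nc3cc(Cl)c(Cl)cc32)cc1` gives 50000 nM. Going by the values given here, compound 2 `Nc1nc2cc(Cl)c(Cl)cc2n1Cc1ccc([N+](=O)[O-])cc1` gives 35000 nM, so the two measured compounds lie within the scatter of each other, and compound 1 stands level with its only neighbour on these numbers. Compound 3 `Cc1ccc(Cn2c(Br)nc3cc(Cl)c(Cl)cc32)cc1` keeps the core of compound 1 but carries bromo in place of amino on an aromatic carbon, between two ring nitrogen atoms: bromo in place of amino on an aromatic carbon. Among the compounds with values here, the only measured step is a 1.4-fold lower number from compound 1 to compound 2 (0.15 log units; within the scatter), and it swaps methyl for nitro elsewhere on the molecule, so it says little about this change. Within the data shown here, no measured pair alters this position, and the data point in neither direction, so no shift beyond the scatter is expected in this assay. The expected change is a 1.4-fold lower number from compound 1 to compound 3 (0.15 log units; within the scatter). Compound 3 is estimated at 35000 nM, with an expected range from 10000 nM to 100000 nM.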

Compound 3, half-maximal inhibitory concentration: > 100000 nM
Compound 3: only a limit was reported (the forecaster's own chance of this, stated with the estimate: 25%); at least 2.8-fold (0.45 log units) between middle value and limit.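

Compound 3 is the first compound shown to change the group on the aromatic carbon between two ring nitrogen atoms, and in this assay its > 100000 nM is a limit, not a number. Bromo in place of amino gives an at least 2.0-fold higher number from compound 1 to compound 3 (0.30 log units; that floor lies within the scatter), so this change brings no gain in inhibition, though the step cannot show a real loss either. The true size of the step stays unknown because compound 3 rests on a limit: the limit of > 100000 nM in this assay, at which 1 of the 3 values shown sits.

The compounds shown leave open whether the outcome at this position depends on losing amino or on gaining bromo. A methylamino group, a hydroxyl group or a plain hydrogen on the same carbon of the shared core would help to separate these two possibilities.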